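The compounds below may be only part of what the source reports. "The series", "measured", "known", "first", "only" and "open" are said of these compounds alone.

In an ADME assay on MT4 cells (Homo sapiens) for cytotoxicity, read by MTT assay, with a stated time of 5 days (a lower number here means that less compound is tolerated, a higher number that more compound is tolerated), compound 1 `COc1cc2nc([S+]([O-])CC(=O)Nc3ccccc3[N+](=O)[O-])nc(Nc3c(Cl)cc(/C=C/C#N)cc3Cl)c2cc1OC` gives > 199000 nM. That value is a limit of the assay and not a number. Among the measured compounds shown here, compound 2 `COc1cc2nc([S+]([O-])CC(=O)Nc3ccc([N+](=O)[O-])cc3)nc(Nc3c(Cl)cc(/C=C/C#N)cc3Cl)c2cc1OC` gives 92800 nM, the only true number so far. For the measured compounds named here, the one measured step, an at least 2.1-fold lower number from compound 1 to compound 2 (0.33 log units; beyond the scatter), came with 4-nitrophenyl in place of 2-nitrophenyl on an amide-type nitrogen. Compound 3 `COc1cc2nc([S+]([O-])CC(=O)Nc3cccc(Cl)c3)nc(Nc3c(Cl)cc(/C=C/C#N)cc3Cl)c2cc1OC` alters the same place again, with 3-chlorophenyl in place of 4-nitrophenyl on an amide-type nitrogen. Going by the values given here, only that one step bears on this change, and it bears loosely. Among the compounds with values here, it shows that a change on this nitrogen can shift the number, yet it exchanged one nitrophenyl for another, its size is open-ended, and no measured compound carries 3-chlorophenyl. Within the data shown here, with an at least 2.1-fold lower number from compound 1 to compound 2 (0.33 log units; beyond the scatter) as the sole guide, no direction can be expected with confidence, and no step beyond the scatter is expected in this assay. The estimated change is a 1.0-fold lower number from compound 2 to compound 3 (0.01 log units; within the scatter). The expected value for compound 3 is 90000 nM, with an estimated range from 30000 nM to 200000 nM.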

Compound 3, half-maximal cytotoxic concentration: 68900 nM
The estimate for compound 3 lay 1.3-fold (0.12 log units) above the measured number; measured number inside the range.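

In this assay, the amide-type nitrogen now carries a group without a nitro substituent, and the number stays within the scatter (a 1.3-fold lower number from compound 2 to compound 3 (0.13 log units; within the scatter)), so compound 2 and compound 3 cannot be told apart here even though 3-chlorophenyl differs from 4-nitrophenyl in its atoms and its count of hydrogen-bond acceptors. The step from the 2-nitrophenyl compound to the 3-chlorophenyl compound (an at least 2.8-fold lower number from compound 1 to compound 3 (0.46 log units; beyond the scatter)) lies beyond the scatter, so among these three compounds, compound 1 alone stands apart, while compound 2 and compound 3 stay together. The true size of that gap cannot be read because the value for compound 1 is a limit and not a number: (the limit of > 199000 nM in this assay, at which 1 of the 3 values shown sits).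

The compounds shown leave open whether the gap belongs to the 2-nitrophenyl group itself or to any group placed as it is there, which a 2-chlorophenyl or 3-nitrophenyl group on the same nitrogen would help to separate. They also leave open how far the number moves with a plain phenyl, a pyridine ring, a carboxylic acid or a longer alkyl chain in this place.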